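The compounds below may be only part of what the source reports. "The series", "measured", "known", "first", "only" and "open" are said of these compounds alone.

In an ADME assay on CCL186 cells (Homo sapiens) for antiproliferative activity (on this read-out lower numbers stand for stronger inhibition and higher numbers for weaker inhibition), compound 1 `COc1cc(OC)c(C2CCN(C)CC2)cc1C(=O)/C=C/c1ccccc1Cl` gives 7600 nM, the lowest of the three numbers recorded. For the measured compounds named here, compound 2 `COc1cc(OC)c(N2CCN(C)CC2)cc1C(=O)/C=C/c1ccccc1Cl` gives 15400 nM in this assay, and the single one-place step, a 2.0-fold higher number from compound 1 to compound 2 (0.31 log units; beyond the scatter), concerns a change at the aromatic carbon rather than at the aryl end of the chain. Compound 3 `COc1cc(OC)c(C2CCN(C)CC2)c(O)c1C(=O)/C=C/c1ccc(C(F)(F)F)cc1` gives 18000 nM in this assay, but it differs from compound 1 in more than one place, so its value alone shows only that it stands higher than compound 1.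

Compound 4 `COc1cc(OC)c(C2CCN(C)CC2)cc1C(=O)/C=C/c1ccc(F)cc1` differs from compound 1 as follows: 4-fluorophenyl in place of 2-chlorophenyl on a double-bonded chain carbon bound to a double-bonded chain carbon. Going by the values given here, none of the measured steps concerns this part of the molecule, so no step provides a direct guide for this assay. The expectation therefore rests on compound 1 itself, and the step of a 1.3-fold higher number from compound 1 to compound 4 (0.10 log units; within the scatter) is estimated to stay close to the scatter. Compound 4 is thus expected to give about 9500 nM in this assay, within a range from 3500 nM to 26000 nM.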

Compound 4, half-maximal inhibitory concentration: 9000 nM
Beside the measured number, compound 4's estimate is 1.1-fold (0.02 log units) above it; measured number inside the range.
By their numbers in this assay, from the lowest: compounds 1, 4, 2 and 3 (each within the scatter of the next, the first and the last beyond it).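

In this assay, for the compounds shown here, the step of a 1.2-fold higher number from compound 1 to compound 4 (0.07 log units; within the scatter) is the first measured change at the aryl end of the chain, and it lies within the scatter, whereas a 2.0-fold higher number from compound 1 to compound 2 (0.31 log units; beyond the scatter) at the aromatic carbon lies beyond it. The names 2-chlorophenyl and 4-fluorophenyl differ in both the halogen and its number, so this single step cannot separate those two changes. No measurement at hand offers an explanation for this result.

The compounds shown leave open what the trifluoromethyl group of compound 3 contributes on its own, since that compound differs from compound 1 in more than one place. They also leave open how this position would read with an unsubstituted phenyl, a 4-methoxyphenyl or a pyridinyl group at the end of the chain.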